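Swapping a Methoxy for Chloro on a Phenyl Ester

The source may hold more compounds than are shown below. What is called first, only, known or untested is meant among the compounds shown, and "the series" means these compounds.

Of the compounds shown here, three have been tested in a functional assay on PC-3 cells (Homo sapiens) for antiproliferative activity, read by sulforhodamine B assay, with a stated time of 48 h, tested at 50 uM; a higher number here means more inhibition at the concentration tested (going by the name of the read-out), a lower number less inhibition. Compound 1 `COc1cccc(C(=O)Oc2cc3c(cc2C)[C@@H](C(C)C)CC=C3C)c1` gives 16.3%, the lowest of the three numbers. Compound 2 `Cc1cc2c(C(C)C)ccc(C)c2cc1OC(=O)c1cccc(C(F)(F)F)c1` gives 26.7%, a gap beyond the usual scatter, and compound 3 `Cc1cc2c(C(C)C)ccc(C)c2cc1OC(=O)c1ccc(C(F)(F)F)cc1` gives 100%, far above both. Compound 4 `CC1=CC[C@H](C(C)C)c2cc(C)c(OC(=O)c3cccc(Cl)c3)cc21` is not yet measured; it differs from compound 1 in one place: chloro in place of methoxy on an aromatic carbon, a chloro in place of methoxy on an aromatic carbon, meta to a large group. Among the measured compounds shown here, since no pair differing in one place has been measured, the size of this step is uncertain. A modest rise is expected, a number 10.7 percentage points higher from compound 1 to compound 4 (beyond the scatter), because compound 2 with a different group at the same kind of carbon gives 26.7%. Compound 4 is therefore estimated at 27%, within 10% to 55%.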

Compound 4, a percentage reported as inhibition, at one concentration (the size of the read-out at that concentration, not a potency): 23.4%
Compound 4: middle estimate off by 3.6 percentage points, on the high side; the measured number falls inside the stated range.
By their numbers in this assay, from the lowest: compounds 1, 4 and 2 (each within the scatter of the next, the first and the last beyond it); then compound 3.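

Among the compounds shown here, on this aromatic carbon, chloro in place of methoxy gives the first step between two compounds differing in one place: in this assay the reading is a number 7.1 percentage points higher from compound 1 to compound 4 (within the scatter) and so the change cannot be told apart from ordinary scatter. At this one concentration, going from 3-methoxyphenyl to 3-chlorophenyl therefore makes no clear difference. Nothing available explains why these two groups read alike. Still open, going by these compounds, is whether an amine or a carboxylic acid on the same carbon would shift the number beyond the scatter.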